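The compounds below may be only part of what the source reports. "The series", "measured", "known", "first", "only" and "open" are said of these compounds alone.

Measured compounds and their values:
- compound 1, `COc1cc(C(=O)O)ccc1OCCCCOc1ccc(C(=O)C(C)C)c(O)c1C`: 25.6%
- compound 2, `COc1cc(C(=O)O)ccc1OCCCCOc1ccc(C(=O)CC(C)C)c(O)c1C`: 73.9%
- compound 3, `Cc1c(OCCCCOc2ccc(C(=O)CC(C)(C)C)c(O)c2C)cccc1C(=O)O`: 109%

In an assay on HEK293 cells for positive allosteric modulation of metabotropic glutamate receptor 3 (Rattus norvegicus), read by thallium flux, with a stated time of 2.5 min (a higher number here means a larger maximal response, a lower number a smaller maximal response), compound 1 stands lowest of the three numbers. Its nearest neighbour is compound 2, and the step of a number 48.3 percentage points higher from compound 1 to compound 2 (beyond the scatter) is a large one. Among the compounds with values here, compound 3 gives a higher number still, beyond the scatter, but it differs from compound 1 in more than one place, so no single step connects the two.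

Compound 4, `Cc1cc(C(=O)O)ccc1OCCCCOc1ccc(C(=O)C(C)C)c(O)c1C`, differs from compound 1 in one place: methyl in place of methoxy on an aromatic carbon. A methoxy leaves and a methyl enters on the ring that carries the carboxy group.

Within the data shown here, none of the measured steps bears on this change. Among the measured compounds shown here, the one step available, from compound 1 to compound 2, alters the chain on the carbonyl carbon and leaves the carboxy-bearing ring untouched. Compound 3 carries a methyl on that ring, but in a different arrangement and together with a different carbonyl chain, so it gives no clean guide either. With nothing to lean on, the expected step of a number 4.4 percentage points higher from compound 1 to compound 4 (within the scatter) is none beyond the scatter. Compound 4 is therefore estimated at 30%, with a range from 12% to 55%.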

Compound 4, largest response reached (reported as percent of maximum), in percent of the reference or control that the assay uses: 25.2%
For compound 4 the middle estimate is 4.8 percentage points above the measured one; measured number inside the range.
By their numbers in this assay, from the lowest: compounds 4 and 1 (each within the scatter of the next); then compound 2; then compound 3.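

In this assay, replacing the methoxy with a methyl on the aromatic carbon ortho to a large group and meta to a carboxy group gives a number 0.4 percentage points lower from compound 1 to compound 4 (within the scatter). Within the data shown here, this is the first look at this position: the only earlier single change, at the chain on a carbonyl carbon, gave a number 48.3 percentage points higher from compound 1 to compound 2 (beyond the scatter), whereas here the loss of one heavy atom and one hydrogen-bond acceptor leaves no difference that this read-out can separate from the scatter, at least in a compound with an isopropyl on the carbonyl carbon and a low maximal response. Nothing in the data shown gives a reason for this result.

As far as these compounds go, whether the same exchange would stay as quiet alongside the isobutyl chain of compound 2, which stands at 73.9%, remains open. Also open, from the compounds shown here alone, is how this position would respond to a different group, such as a chlorine, a fluorine, an ethoxy or a longer ether chain.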